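Chloro in place of methyl on the aromatic ring

The compounds below may be only part of what the source reports. "The series", "measured", "known", "first", "only" and "open" are said of these compounds alone.

In a functional assay on MDA-MB-231 cells (Homo sapiens) for antiproliferative activity, read by MTT assay, with a stated time of 72 h (on this read-out higher numbers stand for weaker inhibition and lower numbers for stronger inhibition), compound 1 (`CC1=CC[C@H]2[C@H](CC[C@]2(C)O)C(C)(C)[C@@H]1CC[C@H]1[C@]2(C)CC[C@H](OC(=O)CCC(=O)O)C(C)(C)O[C@H]2CC[C@@]1(C)O`) gives 27900 nM, compound 2 (`CC1=CC[C@H]2[C@H](CC[C@]2(C)O)C(C)(C)[C@@H]1CC[C@H]1[C@]2(C)CC[C@H](OC(=O)c3ccccc3)C(C)(C)O[C@H]2CC[C@@]1(C)O`) gives 16100 nM and compound 3 (`CC1=CC[C@H]2[C@H](CC[C@]2(C)O)C(C)(C)[C@@H]1CC[C@H]1[C@]2(C)CC[C@H](OC(=O)c3ccc(C)cc3)C(C)(C)O[C@H]2CC[C@@]1(C)O`) gives 33400 nM. Compound 3 is not separated from one neighbour, a 1.2-fold higher number from compound 1 to compound 3 (0.08 log units; within the scatter), but is from the other. Compound 4 (`CC1=CC[C@H]2[C@H](CC[C@]2(C)O)C(C)(C)[C@@H]1CC[C@H]1[C@]2(C)CC[C@H](OC(=O)c3ccc(Cl)cc3)C(C)(C)O[C@H]2CC[C@@]1(C)O`) carries chloro in place of methyl on an aromatic carbon, para to a large group: chloro in place of methyl on an aromatic carbon. Among the compounds with values here, the only measured change at this aromatic carbon, a 2.1-fold higher number from compound 2 to compound 3 (0.32 log units; beyond the scatter), is modest, so only a small move is expected here. The expected step is a 1.5-fold lower number from compound 3 to compound 4 (0.18 log units; within the scatter). The estimate for compound 4 is 22000 nM, with an expected range of 11000 nM to 42000 nM.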

Compound 4, half-maximal inhibitory concentration: 10300 nM
For compound 4 the middle estimate is 2.1-fold (0.33 log units) above the measured one, outside the stated range (below it).
By their numbers in this assay, from the lowest: compounds 4, 2, 1 and 3 (each within the scatter of the next, the first and the last beyond it).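

In this assay methyl and chloro on this aromatic carbon are separated, with a 3.2-fold lower number from compound 3 to compound 4 (0.51 log units; beyond the scatter) in the exchange, so the result depends on which of the two groups sits there. Chloro in place of hydrogen is not separated, with a 1.6-fold lower number from compound 2 to compound 4 (0.19 log units; within the scatter) in that change. Compound 4 is the only aryl ester shown that is separated from the 2-carboxyethyl ester, with a 2.7-fold lower number from compound 1 to compound 4 (0.43 log units; beyond the scatter) across that change. No evidence given here accounts for these differences. On these data alone, how fluoro, methoxy or an amine would read on this aromatic carbon stays open.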